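This account rests on a few compounds, and the source may have more. Where it says the series, first, only, none or still open, it means among the compounds named here.

Compound 1 `Nc1cc(OCc2cccc(Cl)c2)c2nn[nH]c2n1` gives 21 nM in an assay for inhibition of Myeloperoxidase (Homo sapiens), read by Amplex Red, with stated times of 10 min and 15 min; a lower number here means a stronger inhibitor, a higher number a weaker inhibitor. Compound 2 `Cn1ccc(-c2cccc(COc3cc(N)nc4[nH]nnc34)c2)n1`, which carries a 1-methyl-1H-pyrazol-3-yl in place of the chloro on an aromatic carbon, gives 21 nM; the step of no change at the digits printed from compound 1 to compound 2 (within the scatter) lies within the scatter, so compound 2 stands level with compound 1. Compound 3 `Nc1cc(OCc2cccc(-c3ccccc3F)c2)c2nn[nH]c2n1` is the next variation: 2-fluorophenyl in place of 1-methyl-1H-pyrazol-3-yl on an aromatic carbon. Going by the values given here, only the step from compound 1 to compound 2 bears on this change, and it showed no movement, so the swap at the same position is expected to leave this assay essentially unchanged, a 1.2-fold higher number from compound 2 to compound 3 (0.08 log units; within the scatter). Compound 3 is therefore estimated at 25 nM, with a range from 8 nM to 75 nM.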

Compound 3, half-maximal inhibitory concentration: 160 nM
For compound 3 the middle estimate is 6.4-fold (0.81 log units) below the measured one; measured number outside the range, above it.
By their numbers in this assay, from the lowest: compounds 1 and 2 (each within the scatter of the next); then compound 3.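

This position does respond to the group placed on it. In this assay, 2-fluorophenyl in place of 1-methyl-1H-pyrazol-3-yl gives a clear loss (a 7.6-fold higher number from compound 2 to compound 3 (0.88 log units; beyond the scatter)), and 2-fluorophenyl in place of chloro gives the same loss (a 7.6-fold higher number from compound 1 to compound 3 (0.88 log units; beyond the scatter)), so the level result of the earlier swap does not extend to every aromatic ring here. No measurement shown accounts for this rise. Open, from the compounds shown here alone, is whether a plain phenyl, a pyridine ring or a carboxylic acid at this place would read like compound 3 or like compounds 1 and 2. Going by these compounds, the part played by the fluorine also stays open.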